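Methyl for Fluoro on an Aromatic Carbon, Two Cores

This account rests on a few compounds, and the source may have more. Where it says the series, first, only, none or still open, it means among the compounds named here.

Compound 2 `Cc1nc(-c2ccc(C(F)(F)F)cc2)sc1COc1ccc(OCC(=O)O)c(F)c1` is measured in an assay on CHO cells for agonist activity at Free fatty acid receptor 1 (Homo sapiens), read by FLIPR (a lower number here means that less compound is needed, a higher number that more compound is needed for the effect), where compound 2 gives 149 nM. Compound 1 `Cc1cc(OCc2sc(-c3ccc(C(F)(F)F)cc3)nc2C)ccc1OCC(=O)O` differs from it in one place: methyl in place of fluoro on an aromatic carbon. In this assay compound 1 gives only a limit, > 10000 nM. The resulting step is an at least 67-fold higher number from compound 2 to compound 1 (1.82 log units; beyond the scatter), and it ends at the limit of > 10000 nM in this assay, at which 2 of the 3 values shown sit.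

Compound 3 `O=C(O)COc1ccc(OCc2ncc(-c3ccccc3)o2)cc1F` is built on another core; the difference between the two cores is not broken down here. In this assay compound 3 gives only a limit, > 10000 nM.

Compound 4 `Cc1cc(OCc2ncc(-c3ccccc3)o2)ccc1OCC(=O)O` is not yet measured and differs from compound 3 by the same change: methyl in place of fluoro on an aromatic carbon. The expectation for it rests on two things: compound 3 already sits at the limit of > 10000 nM in this assay, at which 2 of the 3 values shown sit, and the step of an at least 67-fold higher number from compound 2 to compound 1 (1.82 log units; beyond the scatter) shows this change moving a compound to that same limit. From compound 3 to compound 4 the step is therefore expected to be a step that the limit leaves unreadable from compound 3 to compound 4. Compound 4 is expected to give 30000 nM, most likely again as a limit rather than a number.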

Compound 4, half-maximal effective concentration: > 10000 nM
Compound 4: no number, only a limit; the forecaster's own chance of this, stated with the estimate: 90%; the middle value does not contradict the limit.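

In this assay compound 3 and compound 4 both give only a limit and not a number, so no step can be read between them: the limit of > 10000 nM in this assay, at which 3 of the 4 values shown sit.

The compounds shown leave open whether methyl in place of fluoro on an aromatic carbon changes the needed concentration at all on the core of compound 3, and how much compound either one would need.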